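Swapping the Aryl Group on the Ring Nitrogen

The source may report more compounds than this note shows. Statements on the series, on what has been measured and on what is new or still open speak of the compounds shown alone.

Measured compounds and their values:
- compound 1, `COc1ccc(N2CCN(C(=S)SCc3ccc(C(=O)Nc4ccccc4N)cc3)CC2)cc1`: 28.1%
- compound 2, `CN(Cc1ccncc1)C(=S)SCc1ccc(C(=O)Nc2ccccc2N)cc1`: 31.4%
- compound 3, `Nc1ccccc1NC(=O)c1ccc(CSC(=S)N2CCc3cc(Cl)ccc32)cc1`: 31.9%

All three share the same core and were tested in a functional assay on A-375 cells (Homo sapiens) for antiproliferative activity, read by CCK-8 assay, with a stated time of 72 h, tested at 2 uM; on this read-out higher numbers stand for a stronger effect at the one concentration tested and lower numbers for a weaker effect. On the numbers shown, compound 1 gives the smallest value of the three, but its gaps to compound 2 and compound 3 are both within the scatter, so the three compounds cannot be told apart on this read-out.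

The unmeasured compound 4, `Nc1ccccc1NC(=O)c1ccc(CSC(=S)N2CCN(c3cnccn3)CC2)cc1`, differs from compound 1 in one place: pyrazin-2-yl in place of 4-methoxyphenyl on an amine nitrogen in a ring. Among the compounds with values here, the only measured step, a number 0.5 percentage points higher from compound 2 to compound 3 (within the scatter), alters the group on the thiocarbonyl carbon rather than the group on the amine nitrogen in the ring, so it does not bear directly on this change; it does show that a sizeable swap elsewhere on the core left this assay unmoved. Within the data shown here, no measured step touches the position changed here.

Compound 4 is therefore expected to sit close to compound 1, with an estimated step of a number 1.9 percentage points higher from compound 1 to compound 4 (within the scatter) that does not exceed the scatter. The estimate for compound 4 is 30%, with a range from 16% to 44%.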

Compound 4, a percentage reported as inhibition, at one concentration (the size of the read-out at that concentration, not a potency): 29.1%
For compound 4 the middle estimate is 0.9 percentage points above the measured one; the measured number falls inside the stated range.
By their numbers in this assay, from the lowest: compounds 1, 4, 2 and 3 (each within the scatter of the next).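

Within the data shown here, this is the first measured change on the amine nitrogen in the ring, and in this assay pyrazin-2-yl in place of 4-methoxyphenyl gives a number 1 percentage points higher from compound 1 to compound 4 (within the scatter) at this one concentration. Among these compounds, an aromatic ring of carbon only can therefore be exchanged for a smaller one with 2 hetero atoms without a readable change in this assay, so the swap on the thiocarbonyl carbon is no longer the only large change seen to leave the read-out unmoved. Nothing available explains this lack of change.

On these data alone, both groups compared here are six-membered aromatic rings, so it remains open whether a simple methyl, a longer alkyl chain or a chain ending in a carboxylic acid on this nitrogen would move the value. A single concentration also leaves open whether compound 1 and compound 4 would differ in potency.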